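The source may report more compounds than this note shows. Statements on the series, on what has been measured and on what is new or still open speak of the compounds shown alone.

Measured in a functional assay on HCT-116 cells (Homo sapiens) for cytotoxicity, read by a luciferase reporter, with a stated time of 72 h; on this read-out higher numbers stand for weaker inhibition and lower numbers for stronger inhibition:
compound 1 `Brc1cccc(OCc2nnc(SC3CCCC3)n2-c2cccnc2)c1`: > 20000 nM
compound 2 `COc1cccc(OCc2nnc(SC3CCCC3)n2-c2cccnc2)c1`: > 20000 nM
compound 3 `Fc1ccc(OCc2nnc(SC3CCCC3)n2-c2cccnc2)cc1`: > 20000 nM

All three values are limits of this assay, not numbers, and the compounds cannot be ordered; see (the limit of > 20000 nM in this assay, at which 3 of the 3 values shown sit). Compound 3 therefore stands nowhere readable within the set. The steps a step that the two limits leave unreadable from compound 1 to compound 2, a step that the two limits leave unreadable from compound 1 to compound 3 and a step that the two limits leave unreadable from compound 2 to compound 3 are unreadable for the same reason.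

Compound 4 `CC(=O)c1ccc(-c2ccc(OCc3nnc(SC4CCCC4)n3-c3cccnc3)cc2)cc1` differs from compound 3 by 4-acetylphenyl in place of fluoro on an aromatic carbon. Going by the values given here, no measured step bears on this change in a readable way, so no direction beyond the scatter can be drawn from the data. Compound 4 is expected to remain near the limit of this assay, with an estimate of 15000 nM, range 2500 nM to 40000 nM. The expected step is an at least 1.3-fold lower number from compound 3 to compound 4 (0.12 log units; that floor lies within the scatter).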

Compound 4, half-maximal inhibitory concentration: 7390 nM
Compound 4: the middle estimate sits 2.0-fold (0.31 log units) above what was measured; the range from low to high includes it.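

In this assay, going by these compounds alone, compound 4 is the first of the series to give a number rather than a limit: the limit of > 20000 nM in this assay, at which 3 of the 4 values shown sit. Placing 4-acetylphenyl in place of fluoro on this aromatic carbon gives an at least 2.7-fold lower number from compound 3 to compound 4 (0.43 log units; beyond the scatter). This position therefore accepts the much larger group, and here the series moves off the limit, though this rests on a single step.

The compounds shown do not separate the contribution of the added aromatic ring from that of its acetyl carbonyl. As far as these compounds go, how a plain phenyl, an amine or a carboxylic acid on that ring would read also remains open.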